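The compounds below may be only part of what the source reports. "The series", "measured", "known", "first", "only" and "open" are said of these compounds alone.

Working notes on the series.

Two compounds have numbers in a functional assay on PANC-1 cells (Homo sapiens) for inhibition, read by MTT assay, with a stated time of 72 h; a lower number here means a stronger inhibitor of growth, a higher number a weaker inhibitor of growth. Compound 1 `O=S(=O)(NCCCNCc1ccccc1Cl)c1cc(C(F)(F)F)cc(C(F)(F)F)c1` gives 15000 nM in this assay. Compound 2 `O=S(=O)(NCCCNCc1cccc(Cl)c1)c1cc(C(F)(F)F)cc(C(F)(F)F)c1`, which carries the chloro at a different position on the benzyl ring, gives 12000 nM in this assay. Going by the values given here, the only step between measured compounds, a 1.3-fold lower number from compound 1 to compound 2 (0.10 log units; within the scatter), is within the scatter, so the two numbers cannot be ordered; compound 2 simply stands with the lower of the two numbers, with compound 1 its only neighbour.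

Compound 3 `COc1cccc(CNCCCNS(=O)(=O)c2cc(C(F)(F)F)cc(C(F)(F)F)c2)c1` is not yet measured. From compound 2 the change is methoxy in place of chloro on an aromatic carbon. Among the compounds with values here, no measured step bears directly on swapping chloro for methoxy; the single step available, from compound 1 to compound 2, moved the chloro and left the number within the scatter, which says nothing about replacing it. With nothing in the series to push the expectation either way, the estimated step of a 1.2-fold higher number from compound 2 to compound 3 (0.07 log units; within the scatter) is no larger than the scatter. Going by these compounds, compound 3 is therefore expected to give about 14000 nM in this assay, with a range from 6000 nM to 35000 nM, the width reflecting that the substituent swap itself is untested here.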

Compound 3, concentration for 50% growth inhibition: 10000 nM
Beside the measured number, compound 3's estimate is 1.4-fold (0.15 log units) above it, and the stated range covers the measured number.
By their numbers in this assay, from the lowest: compounds 3, 2 and 1 (each within the scatter of the next).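

In this assay, going by these compounds alone, methoxy in place of chloro on an aromatic carbon, meta to a large group, gives a 1.2-fold lower number from compound 2 to compound 3 (0.08 log units; within the scatter) and so provides the first direct reading of this swap: at this position, the change cannot be told apart from no change. The wider change to 3-methoxyphenyl in place of 2-chlorophenyl gives a 1.5-fold lower number from compound 1 to compound 3 (0.18 log units; within the scatter) and so also stays inside the scatter, which means that neither step separates these compounds and all three numbers remain unordered in this assay. No supporting evidence is available to explain these results.

Going by these compounds, it remains open whether a different group on this ring, such as an amine or a carboxylic acid, or plain hydrogen in place of the substituent, would give a step beyond the scatter. On these data alone, it is equally open whether a longer chain in the shared core would do so, and whether any result from these three compounds would carry over to a cell line other than the one used here.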